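Cytotoxicity limit carried from compound 2 to compound 4

This account rests on a few compounds, and the source may have more. Where it says the series, first, only, none or still open, it means among the compounds named here.

Working notes on the series. Compound 1 `N=C(NO)N/N=C/c1ccc(Cl)cc1` carries a chloro group on its aromatic ring; in an ADME assay on HeLa cells (Homo sapiens) for cytotoxicity (a lower number here means that less compound is tolerated, a higher number that more compound is tolerated), compound 1 gives > 100000 nM, which is a limit of the assay and not a number. Compound 2 `CN(C)c1ccc(/C=N/NC(=N)NO)cc1` carries a dimethylamino group in its place; in this assay compound 2 gives > 100000 nM, again a limit. Compound 3 `COc1ccccc1/C=N/N=C(\N)NO` carries a methoxy group; in this assay compound 3 gives > 100000 nM, also a limit. Compound 2 therefore stands at the same limit as everything measured so far: the limit of > 100000 nM in this assay, at which 3 of the 3 values shown sit. Going by the values given here, the one step with measured ends, a step that the two limits leave unreadable from compound 1 to compound 2, cannot be read as a size because both ends are limits.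

Compound 4 `COc1ccc(/C=N/NC(=N)NO)cc1` differs from compound 2 by methoxy in place of dimethylamino on an aromatic carbon. Among the compounds with values here, no measured step bears on this change with a readable size; the only step available, from chloro to dimethylamino, left the limit unchanged, and compound 3, which also carries a methoxy group, sits at the same limit. Since compound 2 gives > 100000 nM as a limit, the step that the limit leaves unreadable from compound 2 to compound 4 is expected to be none beyond the scatter, most likely reported again as a limit. Compound 4 is estimated at 150000 nM, with a range from 60000 nM to 500000 nM.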

Compound 4, half-maximal cytotoxic concentration: > 100000 nM
Compound 4 gave a limit, no number; the forecaster's own chance of this, stated with the estimate: 85%; the middle value does not contradict the limit.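

In this assay compound 4 gives > 100000 nM, a limit and not a number. The steps to compound 4 from compound 1 and compound 2 therefore cannot be read: the limit of > 100000 nM in this assay, at which 4 of the 4 values shown sit. The compounds shown leave open whether any group on the aromatic ring gives a cytotoxic concentration readable as a number.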